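Hydroxy Substitution and Expected Cell Toxicity

The source may hold more compounds than are shown below. What is called first, only, known or untested is meant among the compounds shown, and "the series" means these compounds.

Measured so far:
compound 1 `O=c1c(O)c(-c2cc(O)c(O)cc2O)oc2ccc(O)cc12`: > 50000 nM
compound 2 `O=c1c(O)c(-c2ccccc2)oc2cccc(O)c12`: > 50000 nM

In an ADME assay on Huh-7 cells (Homo sapiens) for cytotoxicity, read by MTT assay (on this read-out higher numbers stand for lower toxicity in this test and lower numbers for higher toxicity in this test), compound 1 gives > 50000 nM, which is a limit of the assay and not a number. Compound 2 gives > 50000 nM in this assay, again only a limit. Compound 2 thus stands at the limit of > 50000 nM in this assay, at which 2 of the 2 values shown sit. Compound 3 `O=c1c(O)c(-c2ccc(O)cc2)oc2cccc(O)c12` differs from compound 2 by hydroxy in place of hydrogen on an aromatic carbon. Among the compounds with values here, no measured pair shows what this change does in this assay, and no shift beyond the scatter is expected. The step that the limit leaves unreadable from compound 2 to compound 3 is expected to be none beyond the scatter. Compound 3 is therefore estimated at 80000 nM, ranging from 30000 nM to 300000 nM.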

Compound 3, half-maximal cytotoxic concentration: > 50000 nM
Compound 3 was reported as a limit; the forecaster's own chance of this, stated with the estimate: 85%; the middle value is on the limit's open side.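

No step can be read between compound 2 and compound 3, as both results are limits and not numbers: the limit of > 50000 nM in this assay, at which 3 of the 3 values shown sit.

The compounds shown leave open how far each lies past that limit, and so what hydroxy in place of hydrogen on an aromatic carbon changes.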